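A few compounds are considered here, and "the series" means these few. Any claim that something is new, unique, unknown or untested is made for them only; others in the source may bear on it.

Measured so far in a functional assay on MCF7 cells (Homo sapiens) for inhibition, read by fluorescence, with a stated time of 72 h; a higher number here means a weaker inhibitor, a lower number a stronger inhibitor:

- compound 1 `CC(C)Cn1cnc2c(NC(=N)N)nc(N)nc21` gives 96600 nM
- compound 2 `CCn1cnc2c(NC(=N)N)nc(N)nc21` gives 54300 nM
- compound 3 `CC(C)n1cnc2c(NC(=N)N)nc(NCCO)nc21` gives 12400 nM

Compound 3 stands lowest of the three, and its gaps to compound 2 and compound 1 lie beyond the scatter. Compound 4 `CC(C)[C@H](CO)Nc1nc(NC(=N)N)c2ncn(C(C)C)c2n1` changes compound 3 in one place (isopropyl in place of hydrogen on a saturated chain carbon bound to a nitrogen on an aromatic ring and a saturated chain carbon), turning 2-hydroxyethyl into 1-(hydroxymethyl)-2-methylpropyl. For the measured compounds named here, the only measured step (a 1.8-fold lower number from compound 1 to compound 2 (0.25 log units; within the scatter)) stays within the scatter and lies elsewhere, on a saturated chain carbon bound to an aromatic nitrogen, so it is only a weak guide. No step beyond the scatter is therefore expected in this assay, in either direction. The expected change (a 1.1-fold lower number from compound 3 to compound 4 (0.05 log units; within the scatter)) is small. Compound 4 is estimated at 11000 nM (expected range 3500 nM to 35000 nM).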

Compound 4, half-maximal inhibitory concentration: 10500 nM
Beside the measured number, compound 4's estimate is 1.0-fold (0.02 log units) above it; the range from low to high includes it.
By their numbers in this assay, from the lowest: compounds 4 and 3 (each within the scatter of the next); then compounds 2 and 1 (each within the scatter of the next).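

In this assay, the change from 2-hydroxyethyl to 1-(hydroxymethyl)-2-methylpropyl gives a step (a 1.2-fold lower number from compound 3 to compound 4 (0.07 log units; within the scatter)) that stays within the scatter. For the compounds shown here, this is the first look at this saturated chain carbon: an isopropyl, with its 3 added carbons, can sit there without a step beyond the scatter. No measurement shown offers an explanation for this result.

Going by these compounds, whether a phenyl on this same carbon would move the number remains open. So does the effect of an amine in place of the chain's hydroxyl.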